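The source may hold more compounds than are shown below. What is called first, only, known or untested is meant among the compounds shown, and "the series" means these compounds.

Going by the values given here, compound 3 `COCc1cccc(C[C@H](O)/C=C/[C@H]2COC(=O)N2CCSCCCC(=O)O)c1` is one of three compounds measured in an assay on CHO cells for displacement of a labelled ligand from prostaglandin E2 receptor EP4 subtype (Mus musculus), read by scintillation counting, with a stated time of 60 min (on this read-out lower numbers stand for stronger inhibition and higher numbers for weaker inhibition), where compound 3 gives 7.2 nM. Among those three numbers it stands second highest. Compound 1 `COCc1cccc(C[C@H](O)/C=C/[C@H]2CSC(=O)N2CCSCCCC(=O)O)c1`, which shares the rest of the structure but carries a different atom in its five-membered ring, gives 1.2 nM, the lowest of the three. Compound 2 `O=C(O)CCCSCCN1C(=O)OC[C@@H]1/C=C/[C@@H](O)Cc1cccc(-c2ccccc2)c1` gives 28 nM, the highest. Among the compounds with values here, the only single-point step among the measured compounds runs a 3.9-fold lower number from compound 2 to compound 3 (0.59 log units; beyond the scatter), so replacing a phenyl group at this aromatic carbon with a methoxymethyl group was worth a modest gain in binding.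

Compound 4 `O=C(O)CCCSCCN1C(=O)OC[C@@H]1/C=C/[C@@H](O)Cc1cccc(Cl)c1` is the next compound, and its difference from compound 3 is chloro in place of methoxymethyl on an aromatic carbon. The measured step from compound 2 to compound 3 is the only one that bears on this position, and it shows that the group on this aromatic carbon can shift the number by a modest amount. Within the data shown here, no measured compound carries a chloro group here, so the direction is uncertain; a change of modest size, slightly toward a higher number, is the expectation. Compound 4 is expected to give 12 nM, with a likely range from 3.5 nM to 40 nM. This corresponds to an expected step of a 1.7-fold higher number from compound 3 to compound 4 (0.22 log units; within the scatter).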

Compound 4, inhibition constant: 1.5 nM
Beside the measured number, compound 4's estimate is 8.0-fold (0.90 log units) above it, outside the stated range (below it).
By their numbers in this assay, from the lowest: compounds 1 and 4 (each within the scatter of the next); then compound 3; then compound 2.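

In this assay the group on this aromatic carbon matters more than the earlier pair suggested: chloro in place of methoxymethyl gives a 4.8-fold lower number from compound 3 to compound 4 (0.68 log units; beyond the scatter) and chloro in place of phenyl gives a 19-fold lower number from compound 2 to compound 4 (1.27 log units; beyond the scatter) on the same core. Methoxymethyl, which had looked like a gain over phenyl, now sits in the middle of the three groups tried at this carbon, and the lowest number of the three comes with chloro, a single heavy atom in place of the three of methoxymethyl. No measurement is available to explain this order.

From the compounds shown here alone, three groups are too few to say what sets the order, and it remains open whether a fluoro, a bromo, a methyl or an amine group on this carbon would fall in line with chloro. Going by these compounds, it is also open whether the chloro group would give a similar step on the core of compound 1, which carries a different atom in its five-membered ring.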